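A few compounds are considered here, and "the series" means these few. Any claim that something is new, unique, unknown or untested is made for them only; others in the source may bear on it.

Of the compounds shown here, three have been measured in a functional assay on A549 cells (Homo sapiens) for antiproliferative activity, read by MTT assay, with a stated time of 48 h (a lower number here means a stronger inhibitor, a higher number a weaker inhibitor), so far.

- compound 1 `O=c1cc(-c2ccccc2)oc2cc(O)c(OCCCN3CCCCC3)c(O)c12` gives > 100000 nM as a limit
- compound 2 `COc1cc2oc(-c3ccccc3)cc(=O)c2c2c1OCCCCO2` gives > 100000 nM as a limit
- compound 3 `CCN(CC)CCCCOc1c(OC)cc2oc(-c3ccccc3)cc(=O)c2c1O` gives 35000 nM

Compound 3 is the only one of the three with a number. Compound 1 and compound 2 stand at the limit of > 100000 nM in this assay, at which 2 of the 3 values shown sit, which is a limit and not a number.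

Compound 4 `COc1cc2oc(-c3ccccc3)cc(=O)c2c(O)c1OCCCCN1CCCC1` carries pyrrolidin-1-yl in place of diethylamino on a saturated chain carbon, four bonds along the chain from an oxygen on an aromatic ring, and the difference reads pyrrolidin-1-yl in place of diethylamino on a saturated chain carbon, four bonds along the chain from an oxygen on an aromatic ring as counted. Within the data shown here, no measured pair shows this swap, so the expectation rests on compound 3 at 35000 nM and no step beyond the usual scatter is expected in this assay here. The expected change is a 1.1-fold lower number from compound 3 to compound 4 (0.04 log units; within the scatter) and no more. Compound 4 is estimated at 32000 nM with an expected range from 14000 nM to 75000 nM as its likely span.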

Compound 4, half-maximal inhibitory concentration: 13000 nM
Compound 4: middle estimate off by 2.5-fold (0.39 log units), on the high side; measured number below the stated range.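

On a saturated chain carbon, four bonds along the chain from an oxygen on an aromatic ring, the choice of amine registers in this assay: pyrrolidin-1-yl in place of diethylamino brings a 2.7-fold lower number from compound 3 to compound 4 (0.43 log units; beyond the scatter). The two groups match in heavy atoms and differ in the ring, so this position responds to a change of amine shape without a change of atom count. Compound 1 and compound 2 remain limits and not numbers, so no step to either can be read: the limit of > 100000 nM in this assay, at which 2 of the 4 values shown sit.

As far as these compounds go, whether morpholin-4-yl at this position, or a longer chain carrying pyrrolidin-1-yl, would move the number further stays open.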